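The compounds below may be only part of what the source reports. "The series", "measured", "known", "first", "only" and "open" are said of these compounds alone.

Measured in a functional assay on a cell-free system (Platelet, plasma, Homo sapiens) for inhibition; on this read-out lower numbers stand for stronger inhibition and higher numbers for weaker inhibition:
compound 1, `Cc1ccc(N(CCN2CCC(OCC(=O)O)CC2)C(=O)c2cccc(Cl)c2)cc1`, gives 100 nM;
compound 2, `COc1cccc(C(=O)N(CCN2CCC(OCC(=O)O)CC2)c2ccc(C)cc2)c1`, gives 32 nM;
compound 3, `O=C(O)COC1CCN(CCN(C(=O)c2ccc(Cl)cc2)c2ccc(Cl)cc2)CC1`, gives 1500 nM.

Compound 4, `COc1ccc(C(=O)N(CCN2CCC(OCC(=O)O)CC2)c2ccc(Cl)cc2)cc1`, has not yet been measured in this assay. Among the measured compounds shown here, the single change from compound 1 to compound 2 is methoxy in place of chloro on an aromatic carbon, and it produced a 3.1-fold lower number from compound 1 to compound 2 (0.49 log units; beyond the scatter). The change from compound 3 to compound 4 is methoxy in place of chloro on an aromatic carbon. The two changes are the same kind of change, not the same: in the first the group sits meta to a large group, in the second para to a large group. The difference between the cores of compound 1 and compound 3 is not broken down here; compound 3 gives the highest number of the three measured compounds. A step in the same direction is expected for compound 4 because the earlier step read a 3.1-fold lower number from compound 1 to compound 2 (0.49 log units; beyond the scatter), though the different place and the different core leave its size uncertain. Compound 4 is therefore expected to give 600 nM, within 200 nM to 2500 nM. The expected step is a 2.5-fold lower number from compound 3 to compound 4 (0.40 log units; beyond the scatter).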

Compound 4, half-maximal inhibitory concentration: 3100 nM
Estimate against measurement, compound 4: 5.2-fold (0.71 log units) below; the whole stated range lies below it.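

In this assay, methoxy in place of chloro on an aromatic carbon gave a 2.1-fold higher number from compound 3 to compound 4 (0.32 log units; beyond the scatter), and set beside the earlier step, the change did not keep its direction from one core to the other: the same change on two cores in this assay, a 3.1-fold lower number (0.49 log units; beyond the scatter) from compound 1 to compound 2 and a 2.1-fold higher number (0.32 log units; beyond the scatter) from compound 3 to compound 4, 6.5-fold (0.81 log units) apart, beyond the scatter of two such steps. In this series, then, the step read on one core cannot be carried to the other as a rule, not even in its sign. This does not show what sets the two steps apart: the group sits in a different place in each pair and the cores differ as well, and two steps cannot separate these differences or show how the change would read on any further core.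

The compounds shown leave open how the same change would read on the core of compound 3 with the group in the place it holds in compound 2. They also leave open how fluoro or an amine on that aromatic carbon would compare with chloro and methoxy.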